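Chain-terminal carboxy against methyl in a norbornane-derived amide series

A few compounds are considered here, and "the series" means these few. Any claim that something is new, unique, unknown or untested is made for them only; others in the source may bear on it.

The study concerns four compounds built on one shared core. Compound 1 `CCCCNC(=O)C1C(C(=O)O)[C@@H]2CC[C@H]1O2` carries a butyl chain on the amide nitrogen, compound 2 `O=C(O)CCCNC(=O)C1C(C(=O)O)[C@@H]2CC[C@H]1O2` and compound 3 `O=C(O)CCCCCCCNC(=O)C1C(C(=O)O)[C@@H]2CC[C@H]1O2` carry chains ending in a carboxy group, and compound 4 `CCCCCCCCNC(=O)C1C(C(=O)O)[C@@H]2CC[C@H]1O2` carries an octyl chain. In an ADME assay on HT-29 cells (Homo sapiens) for cytotoxicity, read by MTT assay, with a stated time of 72 h (on this read-out higher numbers stand for weaker inhibition of growth and lower numbers for stronger inhibition of growth), compound 1 gives 10000 nM, compound 2 gives 10000 nM and compound 3 gives 10000 nM.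

The difference between compound 2 and compound 1 is methyl in place of carboxy on a saturated chain carbon, three bonds along the chain from an amide-type nitrogen, and the step it made was no change at the digits printed from compound 2 to compound 1 (within the scatter). The cores of compound 2 and compound 3 differ by 4-carboxybutyl in place of carboxy on a saturated chain carbon, three bonds along the chain from an amide-type nitrogen, with a step of no change at the digits printed from compound 2 to compound 3 (within the scatter); between compound 1 and compound 3 the step was no change at the digits printed from compound 1 to compound 3 (within the scatter).

From compound 3 to compound 4 the difference is methyl in place of carboxy on a saturated chain carbon, seven bonds along the chain from an amide-type nitrogen. This is the same kind of change as that from compound 2 to compound 1, but the place is not the same: there the exchange stood three bonds along the chain from the amide-type nitrogen, here it stands seven bonds along. Because the earlier exchange gave no change at the digits printed from compound 2 to compound 1 (within the scatter), and because every chain variation shown gave no change at the digits printed from compound 1 to compound 3 (within the scatter), the step expected from compound 3 to compound 4 is estimated at no change at the digits printed from compound 3 to compound 4 (within the scatter). In this assay compound 4 is therefore expected to give about 10000 nM, with an estimated range from 4000 nM to 25000 nM.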

Compound 4, concentration for 50% growth inhibition: 10000 nM
The estimate for compound 4 equals the measured number at the digits printed, within the range that was stated.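

In this assay, methyl in place of carboxy on a saturated chain carbon, seven bonds along the chain from an amide-type nitrogen, gave no change at the digits printed from compound 3 to compound 4 (within the scatter); the two other new comparisons read alike, with no change at the digits printed from compound 2 to compound 4 (within the scatter) and no change at the digits printed from compound 1 to compound 4 (within the scatter). The exchange of carboxy for methyl therefore carried over from one core to the other in the sense that it left the read-out level on both: the same change on two cores in this assay, no change at the digits printed (within the scatter) from compound 2 to compound 1 and no change at the digits printed (within the scatter) from compound 3 to compound 4, 1.0-fold (0.00 log units) apart, within the scatter of two such steps. This is agreement between two steps that show no movement, and with all four compounds level it does not show how the same change would behave on a core whose growth inhibition stood at a different value, nor whether the exchange has any effect of its own in this series.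

The compounds shown leave open whether another group on these chains, such as an amine or a hydroxy group, or a chain longer than octyl, would move the value in this assay. They also leave open whether an ester in place of the carboxy group on the shared core would change the picture.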